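Furan for thiophene on the amide of a urotensin-2 ligand series

The compounds below may be only part of what the source reports. "The series", "measured", "known", "first", "only" and "open" are said of these compounds alone.

Compound 1 `CN(C)CCCOc1ccc(CN2CC[C@H](NC(=O)c3cccs3)C2)cc1` and compound 2 `CN(C)CCCOc1ccc(CN2CC[C@H](NC(=O)c3ccco3)C2)cc1` share one core; compound 2 carries furan-2-yl in place of thiophen-2-yl on a carbonyl carbon. In an assay on HEK293 cells for binding affinity to Urotensin-2 receptor (Homo sapiens), read by radioligand binding (a lower number here means a stronger inhibitor, a higher number a weaker inhibitor), compound 1 reaches only a limit, < 10000 nM. In this assay compound 2 likewise reaches only a limit, < 10000 nM. The step that the two limits leave unreadable from compound 1 to compound 2 is therefore of no readable size, because of the limit of < 10000 nM in this assay, at which 2 of the 3 values shown sit.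

Compound 3 `CC(C)C[C@H](NC(=O)c1cccs1)C(=O)N[C@H]1CCN(Cc2ccc(OCCCN(C)C)cc2)C1` carries a leucine-derived amide between the thiophene carbonyl and the pyrrolidine amine; the difference between its core and the core of compound 1 is not broken down here. In this assay, among the measured compounds shown here, compound 3 gives 398 nM, the only number among the three values seen so far.

Compound 4 `CC(C)C[C@H](NC(=O)c1ccco1)C(=O)N[C@H]1CCN(Cc2ccc(OCCCN(C)C)cc2)C1`, not yet measured, differs from compound 3 by furan-2-yl in place of thiophen-2-yl on a carbonyl carbon. This is the same change as that from compound 1 to compound 2, and it is made at the same place, on a carbonyl carbon whose other neighbour is an amide-type nitrogen. For the measured compounds named here, the earlier pair gives no size for the step, so nothing measured says whether the exchange moves affinity in either direction. In this assay the step is expected to stay within the usual scatter, at about a 1.4-fold higher number from compound 3 to compound 4 (0.14 log units; within the scatter), since compound 3 gives 398 nM and the step that the two limits leave unreadable from compound 1 to compound 2 is unreadable. Compound 4 is accordingly estimated at 550 nM, with a range from 150 nM to 2500 nM.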

Compound 4, inhibition constant: 631 nM
Beside the measured number, compound 4's estimate is 1.1-fold (0.06 log units) below it; the range from low to high includes it.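

In this assay the change to furan-2-yl in place of thiophen-2-yl on a carbonyl carbon is read on one core only, as a 1.6-fold higher number from compound 3 to compound 4 (0.20 log units; within the scatter), so on the core of compound 3 this measurement does not tell the two rings apart. On these data alone, the same change on the core of compound 1 has no readable size, and the step cannot be read because compound 1 and compound 2 each stand only at a limit: the limit of < 10000 nM in this assay, at which 2 of the 4 values shown sit. The notes therefore hold a single sized instance of this change, which shows that the exchange is tolerated on the core of compound 3 but does not show that a step of similar size applies on the core of compound 1, so carrying the change from one core to another remains untested by any number.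

Still open, as far as these compounds go, is whether another group on the same carbonyl carbon, such as phenyl or pyridin-2-yl, would give a step beyond the scatter on either core. Also open, from the compounds shown here alone, is how the amide link in compound 3 and compound 4 responds to a different amino acid residue, such as a glycine-derived or phenylalanine-derived amide, or how a longer chain on the dimethylamino end would read in this assay.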